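The source may hold more compounds than are shown below. What is called first, only, known or untested is meant among the compounds shown, and "the series" means these compounds.

Compound 1 `CCNC(=O)CC[C@H](NS(=O)(=O)c1ccc([N+](=O)[O-])cc1)C(=O)O`: 221000 nM
Compound 2 `CC(C)NC(=O)CC[C@H](NS(=O)(=O)c1ccc([N+](=O)[O-])cc1)C(=O)O`: > 500000 nM (a limit)

Going by the values given here, in a functional assay on A549 cells (Homo sapiens) for cytotoxicity, read by MTT assay, with a stated time of 48 h (a higher number here means a weaker inhibitor, a lower number a stronger inhibitor), compound 1 gives 221000 nM, the only actual number so far. Compound 2 gives > 500000 nM, which is a limit of the assay and not a number.

Compound 3 `CCCCNC(=O)CC[C@H](NS(=O)(=O)c1ccc([N+](=O)[O-])cc1)C(=O)O` has not yet been measured. Its difference from compound 1 is this: ethyl in place of hydrogen on a saturated chain carbon, two bonds along the chain from an amide-type nitrogen. Put another way, ethylamino becomes butylamino.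

Among the compounds with values here, one measured step bears on this change: an at least 2.2-fold higher number from compound 1 to compound 2 (0.35 log units; beyond the scatter), which lies beyond the scatter. There, methyl takes the place of hydrogen on a saturated chain carbon bound to an amide-type nitrogen, a different carbon from the one changed here. From the compounds shown here alone, that step ends at the limit of > 500000 nM in this assay, at which 1 of the 2 values shown sits, so its full size is unknown.

With this single step as a guide, the expected step is a 1.6-fold higher number from compound 1 to compound 3 (0.20 log units; within the scatter), towards weaker inhibition. The estimate for compound 3 is 350000 nM, with an expected range of 120000 nM to 900000 nM.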

Compound 3, half-maximal inhibitory concentration: 276000 nM
For compound 3 the middle estimate is 1.3-fold (0.10 log units) above the measured one; measured number inside the range.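

In this assay, ethyl in place of hydrogen, two bonds along the chain from an amide-type nitrogen, gives a 1.2-fold higher number from compound 1 to compound 3 (0.10 log units; within the scatter), so the longer straight chain leaves the number within the usual scatter of compound 1. Butyl in place of isopropyl on the amide-type nitrogen gives an at least 1.8-fold lower number from compound 2 to compound 3 (0.25 log units; that floor lies within the scatter). Compound 2 carries a limit of the assay and not a number, so the full size of this step is unknown and no order between straight and branched chains can be claimed: the limit of > 500000 nM in this assay, at which 1 of the 3 values shown sits.

The compounds shown leave open whether a longer chain such as octyl, or a chain carrying an amine, would move the number beyond the scatter. They also leave open whether the ethylamino to butylamino change would behave the same way on a different core.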